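Swapping the Fluorophenyl for Methylphenyl on a Benzamide Sulfide

The source may report more compounds than this note shows. Statements on the series, on what has been measured and on what is new or still open speak of the compounds shown alone.

Of the compounds shown here, three have been measured in a functional assay on A-375 cells (Homo sapiens) for inhibition, read by CCK-8 assay, with a stated time of 72 h, tested at 8 uM; a lower number here means less inhibition of growth, a higher number more inhibition of growth at the concentration tested. Compound 1 `Nc1ccccc1NC(=O)/C=C/c1ccc(CSc2cccc(F)c2)cc1` gives 9.08%. Compound 2 `Nc1ccccc1NC(=O)c1ccc(CSc2cccc(F)c2)cc1` has a different core; the difference between the two cores is not broken down here. In this assay compound 2 gives 76.3%, the highest of the three. Compound 3 `Cc1ccc(SCc2ccc(/C=C/C(=O)Nc3ccccc3N)cc2)cc1` shares the core of compound 1. In this assay compound 3 gives 31.2%. The change from compound 1 to compound 3 is 4-methylphenyl in place of 3-fluorophenyl on a sulfur and it made a step of a number 22.1 percentage points higher from compound 1 to compound 3 (beyond the scatter). Compound 4 `Cc1ccc(SCc2ccc(C(=O)Nc3ccccc3N)cc2)cc1` is not yet measured; it arises from compound 2 by the same change, (4-methylphenyl in place of 3-fluorophenyl on a sulfur), at the same place. The step expected here is a number 9.7 percentage points higher from compound 2 to compound 4 (within the scatter), somewhat smaller than the earlier one because compound 2 already starts from 76.3%. The estimate for compound 4 is 86%, between 70% and 97%.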

Compound 4, percent growth inhibition at one concentration: 67%
The estimate for compound 4 lay 19 percentage points above the measured number; measured number outside the range, below it.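

In this assay, putting 4-methylphenyl in place of 3-fluorophenyl on the sulfur gives a number 9.3 percentage points lower from compound 2 to compound 4 (within the scatter) and so makes no clear difference on this core. The same change did not behave alike on the two cores: the same change on two cores in this assay, a number 22.1 percentage points higher (beyond the scatter) from compound 1 to compound 3 and a number 9.3 percentage points lower (within the scatter) from compound 2 to compound 4, 31.4 percentage points apart, beyond the scatter of two such steps. This shows that the step seen on one core could not be carried over to the other in this series, but it does not show why, and one pair on each core gives no rule for any further core.

On these data alone, how an amine, a carboxylic acid or a longer chain on the sulfur would fare on either core stays open. As far as these compounds go, whether the gap between the two steps would hold at other test concentrations also stays open.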